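Sulfonyl aryl swap on the shared core: pyridyl to imidazolyl

This account rests on a few compounds, and the source may have more. Where it says the series, first, only, none or still open, it means among the compounds named here.

Compound 1 `CC1CCN(C2CCN(S(=O)(=O)c3ccc(C#N)cc3)CC2)CC1` is the reference point of the series: in a functional assay on DLD-1 cells (Homo sapiens) for antiproliferative activity, read by CellTiter-Glo, with a stated time of 72 h (a higher number here means a weaker inhibitor, a lower number a stronger inhibitor), compound 1 gives 2800 nM. Compound 2 `CC1CCN(C2CCN(S(=O)(=O)c3cccnc3F)CC2)CC1` carries the 2-fluoropyridin-3-yl group on the sulfonyl sulfur in place of 4-cyanophenyl. In this assay compound 2 gives only a limit, > 5000 nM, and no number. The step is an at least 1.7-fold higher number from compound 1 to compound 2 (0.25 log units; that floor lies within the scatter), so compound 2 stands at the limit of > 5000 nM in this assay, at which 1 of the 2 values shown sits, and its true position is open-ended. Compound 3 `CC1CCN(C2CCN(S(=O)(=O)c3nccn3C)CC2)CC1` differs from compound 2 by 1-methyl-1H-imidazol-2-yl in place of 2-fluoropyridin-3-yl on a sulfonyl sulfur. For the measured compounds named here, no measured step covers this particular exchange of aromatic rings; the only guide is an at least 1.7-fold higher number from compound 1 to compound 2 (0.25 log units; that floor lies within the scatter), which shows that changing the aryl group on the sulfonyl sulfur once already pushed the number to the limit. The expected step is therefore a step that the limit leaves unreadable from compound 2 to compound 3, essentially none beyond the scatter, with a real chance that compound 3 again returns only a limit. Compound 3 is estimated at 6000 nM, between 2500 nM and 15000 nM.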

Compound 3, half-maximal inhibitory concentration: > 5000 nM
Compound 3 gave a limit, no number; the forecaster's own chance of this, stated with the estimate: 60%; the middle value is on the limit's open side.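

Replacing 4-cyanophenyl on the sulfonyl sulfur with a five-membered aromatic ring, 1-methyl-1H-imidazol-2-yl, also gives a limit rather than a number in this assay: an at least 1.7-fold higher number from compound 1 to compound 3 (0.25 log units; that floor lies within the scatter). The step between the limits of compound 2 and compound 3 cannot be read, so the data place neither 1-methyl-1H-imidazol-2-yl nor 2-fluoropyridin-3-yl ahead of the other. A second aromatic ring type at this position now ends in the same limit, and only compound 1 keeps a number: the limit of > 5000 nM in this assay, at which 2 of the 3 values shown sit.

As far as these compounds go, how far compound 2 and compound 3 lie past the limit stays open, as does whether the true gap to compound 1 exceeds the scatter. Also open, from the compounds shown here alone, is whether a phenyl ring carrying an amine or a carboxylic acid in place of the nitrile would return a number.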